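Thiophen-3-yl in Place of Naphthalen-1-yl on the Core

The source may hold more compounds than are shown below. What is called first, only, known or untested is meant among the compounds shown, and "the series" means these compounds.

Measured compounds:
compound 1 `COc1ccc(-c2cn3ccnc3c(-c3ccc4ncn(C5CCCCC5)c4c3)n2)cc1` – 62.6%
compound 2 `c1ccc2c(-c3cn4ccnc4c(-c4ccc5ncn(C6CCCCC6)c5c4)n3)cccc2c1` – 2.23%

In a functional assay on HCC 2998 cells (Homo sapiens) for inhibition, read by sulforhodamine B assay, with a stated time of 48 h, tested at 10 uM (a higher number here means more inhibition at the concentration tested (going by the name of the read-out), a lower number less inhibition), compound 1 gives 62.6%, and compound 2 gives 2.23%. Compound 2 thus stands lowest of the two numbers in this assay, and its nearest neighbour is compound 1; the change between them is a number 60.4 percentage points lower from compound 1 to compound 2 (beyond the scatter), a large step that lies beyond the scatter.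

The unmeasured compound 3 `c1cn2cc(-c3ccsc3)nc(-c3ccc4ncn(C5CCCCC5)c4c3)c2n1` differs from compound 2 in a single place: thiophen-3-yl in place of naphthalen-1-yl on an aromatic carbon. Among the measured compounds shown here, no measured step shows the effect of thiophen-3-yl itself. For the measured compounds named here, the one step that bears on compound 3 is a number 60.4 percentage points lower from compound 1 to compound 2 (beyond the scatter), which records how much was lost when naphthalen-1-yl entered in place of 4-methoxyphenyl. Because a number 60.4 percentage points lower from compound 1 to compound 2 (beyond the scatter) was so large, the removal of naphthalen-1-yl in compound 3 is expected to recover part of that loss, though how much a thiophen-3-yl group gives back cannot be read from the two measured compounds. The step in this assay is therefore estimated as a number 32.8 percentage points higher from compound 2 to compound 3 (beyond the scatter), upward and beyond the scatter. Compound 3 is estimated at 35%, with a range from 5% to 70%.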

Compound 3, a percentage reported as inhibition, at one concentration (the size of the read-out at that concentration, not a potency): 2.18%
Estimate against measurement, compound 3: 32.8 percentage points above; measured number below the stated range.
By their numbers in this assay, from the lowest: compounds 3 and 2 (each within the scatter of the next); then compound 1.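

In this assay, thiophen-3-yl in place of naphthalen-1-yl gives a number 0.1 percentage points lower from compound 2 to compound 3 (within the scatter), so on this aromatic carbon of the six-membered aromatic ring with 2 nitrogen, a group of 5 heavy atoms with one five-membered aromatic ring reads the same as one of 10 heavy atoms with 2 six-membered aromatic rings. Thiophen-3-yl in place of 4-methoxyphenyl gives a number 60.4 percentage points lower from compound 1 to compound 3 (beyond the scatter), a step of the same large size as the earlier one with naphthalen-1-yl. The earlier loss is therefore not particular to naphthalen-1-yl: of the three groups seen at this position, only 4-methoxyphenyl stands beyond the scatter of the others, though three compounds support no wider rule. Nothing measured here explains why these numbers fall as they do.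

The compounds shown leave open whether the number for compound 1 goes with the methoxy group or with the phenyl ring that carries it, a question that an unsubstituted phenyl or a 4-hydroxyphenyl group would address. Also open, as far as these compounds go, is whether a 4-aminophenyl or a 4-fluorophenyl group would read like 4-methoxyphenyl or like the other two groups.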